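The source may report more compounds than this note shows. Statements on the series, on what has been measured and on what is new or still open speak of the compounds shown alone.

Measured in an ADME assay on the whole organism (serum) for protein binding, with Homo sapiens as the target, using equilibrium dialysis:
- compound 1 `Cn1cc(-c2ccc(Cn3cc(C(=O)O)c(=O)c4sccc43)cc2)cn1`: 93.4%
- compound 2 `Nc1cccc(-c2ccc(Cn3cc(C(=O)O)c(=O)c4sccc43)nc2)c1`: 88.3%

Within the data shown here, compound 2 lies within the scatter of compound 1, the only other compound measured, so the numbers do not separate the two. Compound 3 `Cn1cc(-c2ccc(Cn3cc(C(=O)O)c(=O)c4sccc43)nc2)cn1` carries 1-methyl-1H-pyrazol-4-yl in place of 3-aminophenyl on an aromatic carbon. Among the measured compounds shown here, no measured step covers this change, so nothing beyond the scatter is expected in this assay, and no direction can be firmly assigned. The expected step is a 1.2-fold lower unbound fraction from compound 2 to compound 3 (0.07 log units; within the scatter). The estimate for compound 3 is 90%, with an expected range of 82% to 96%.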

Compound 3, plasma protein binding: 72.1%
Estimate against measurement, compound 3: 2.8-fold (0.45 log units) (unbound fraction) below; measured number outside the range, below it.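

In this assay, 1-methyl-1H-pyrazol-4-yl in place of 3-aminophenyl on this aromatic carbon gives a 2.4-fold higher unbound fraction from compound 2 to compound 3 (0.38 log units; beyond the scatter) and so shows a modest step beyond the scatter. The group at this position can therefore move the read-out, which the within-scatter gap between the two earlier compounds did not show. No measured evidence bears on the reason for this step. The compounds shown leave open whether the step follows the loss of the amine or the change of ring, as both change together. A plain phenyl at this position would separate the two.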